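This account rests on a few compounds, and the source may have more. Where it says the series, first, only, none or still open, it means among the compounds named here.

Measured in a functional assay on NCI-H460 cells (Homo sapiens) for cytotoxicity, read by MTT assay, with a stated time of 48 h; a lower number here means a stronger inhibitor, a higher number a weaker inhibitor:

- Compound 1 `C=C1C(=O)O[C@H]2CC3=C[C@H](C/C(C)=C/[C@@H](OC(=O)/C=C/c4ccccc4)[C@H]12)OC3=O`: > 10000 nM, a limit of the assay and not a number
- Compound 2 `C=C1C(=O)O[C@H]2CC3=C[C@H](C/C(C)=C/[C@@H](OC(=O)/C=C/c4ccc(N(C)C)cc4)[C@H]12)OC3=O`: 1300 nM
- Compound 3 `C=C1C(=O)O[C@H]2CC3=C[C@H](C/C(C)=C/[C@@H](OC(=O)CCCCC)[C@H]12)OC3=O`: 5900 nM

Of the two values that are true numbers, the higher belongs to compound 3, at 5900 nM. The gap separating them is a 4.5-fold higher number from compound 2 to compound 3 (0.66 log units; beyond the scatter).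

The next analogue is compound 4 `C=C1C(=O)O[C@H]2CC3=C[C@H](C/C(C)=C/[C@@H](OC(=O)C(C)(C)CC)[C@H]12)OC3=O`. It keeps the shared core and the same atoms, but they are joined differently: 1,1-dimethylpropyl in place of pentyl on a carbonyl carbon.

Going by the values given here, no measured step exchanges one such chain for another. The closest evidence comes from two steps that replace a whole group on this same carbonyl carbon. One is an at least 1.6-fold lower number from compound 1 to compound 3 (0.22 log units; that floor lies within the scatter), and the other is a 4.5-fold higher number from compound 2 to compound 3 (0.66 log units; beyond the scatter). Both exchange a 2-phenylethenyl-type group for pentyl, a much larger change than the one made here, and even they were no more than modest in size. In this assay, a step beyond the scatter is therefore not expected, and neither direction is favoured. The expected step is a 1.0-fold higher number from compound 3 to compound 4 (0.01 log units; within the scatter). A reading that stops at the limit of the assay remains possible. The estimate for compound 4 is 6000 nM, with an expected range of 2500 nM to 14000 nM.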

Compound 4, half-maximal inhibitory concentration: 6100 nM
Estimate against measurement, compound 4: 1.0-fold (0.01 log units) below; low and high end bracket the measured number.
By their numbers in this assay, from the lowest: compound 2; then compounds 3 and 4 (each within the scatter of the next). At a limit, above all of these: compound 1.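

In this assay, this exchange of one chain for another on this carbonyl carbon leaves 1,1-dimethylpropyl and pentyl within the scatter of each other: a 1.0-fold higher number from compound 3 to compound 4 (0.01 log units; within the scatter). The branched chain also sits apart from the 2-(4-(dimethylamino)phenyl)ethenyl group, a 4.7-fold higher number from compound 2 to compound 4 (0.67 log units; beyond the scatter), much as the straight chain does, a 4.5-fold higher number from compound 2 to compound 3 (0.66 log units; beyond the scatter), so in these compounds the gap to compound 2 does not depend on which of the two chains is present. The remaining step gives only a floor, and that floor lies within the scatter: an at least 1.6-fold lower number from compound 1 to compound 4 (0.21 log units; that floor lies within the scatter). Compound 1 stands at a limit of the assay and not a number: the limit of > 10000 nM in this assay, at which 1 of the 4 values shown sits.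

The compounds shown leave open whether a shorter or a longer chain on this carbonyl carbon, or a cyclohexyl group in place of the open chains, would also match pentyl and 1,1-dimethylpropyl in this assay. They also leave open whether a chain ending in an amine or a carboxylic acid would come closer to compound 2 than these two chains do, or whether other groups on the aromatic ring, such as methoxy or a halogen, would give a number at all.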